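Ring size at the carbamate nitrogen: cyclopropyl to cyclobutyl

The source may report more compounds than this note shows. Statements on the series, on what has been measured and on what is new or still open speak of the compounds shown alone.

Measured compounds:
compound 1 `COc1ccc(CC(=O)O)cc1-c1ccc(C(F)(F)F)cc1CNC(=O)OCc1ccccc1` — 709 nM
compound 2 `COc1ccc(CC(=O)O)cc1-c1ccc(C(F)(F)F)cc1CN(C(=O)OCc1ccccc1)C1CC1` — 10 nM

Two compounds share one core and differ only in what sits on the carbamate-type nitrogen. In an assay on isolated protein for inhibition of prostaglandin D2 receptor 2 (Homo sapiens), read by flow cytometry, with stated times of 15 min and 5 min (on this read-out lower numbers stand for stronger inhibition and higher numbers for weaker inhibition), compound 1 gives 709 nM. Compound 2 gives 10 nM in this assay, the lowest of the two numbers, and the step of a 71-fold lower number from compound 1 to compound 2 (1.85 log units; beyond the scatter) shows that changing the group on this nitrogen can move the number a great deal.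

Compound 3 `COc1ccc(CC(=O)O)cc1-c1ccc(C(F)(F)F)cc1CN(C(=O)OCc1ccccc1)C1CCC1` is the next member. Its change from compound 2 is cyclobutyl in place of cyclopropyl on an amide-type nitrogen. Among the compounds with values here, no measured pair shows exactly this kind of swap, one small carbon ring for a slightly larger one. Within the data shown here, the single measured step, a 71-fold lower number from compound 1 to compound 2 (1.85 log units; beyond the scatter), says only that putting a ring there instead of hydrogen helped strongly; it does not say how one ring size compares with another. Among the measured compounds shown here, with no closer precedent, the expectation for a 1.2-fold higher number from compound 2 to compound 3 (0.08 log units; within the scatter) is a step within the usual scatter, with no clear direction. The estimate for compound 3 in this assay is therefore 12 nM, with a range from 4 nM to 40 nM.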

Compound 3, half-maximal inhibitory concentration: 14 nM
Estimate against measurement, compound 3: 1.2-fold (0.07 log units) below, within the range that was stated.
By their numbers in this assay, from the lowest: compounds 2 and 3 (each within the scatter of the next); then compound 1.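

In this assay, the step of a 1.4-fold higher number from compound 2 to compound 3 (0.15 log units; within the scatter) means that cyclobutyl and cyclopropyl on this amide-type nitrogen cannot be told apart, so the one extra ring carbon makes no detectable difference here. The large gain over the hydrogen of compound 1 also holds for the second ring, with a 51-fold lower number from compound 1 to compound 3 (1.70 log units; beyond the scatter) as its size, so that gain is not tied to cyclopropyl alone. Nothing available here explains why either ring gives so much lower a number than hydrogen.

The compounds shown leave open how far ring size can grow, since a larger ring such as cyclopentyl or cyclohexyl could keep the number this low or could lose the gain. They also leave open whether a ring is needed at all, because an open chain such as methyl, ethyl or isopropyl on the same nitrogen would separate the effect of having a ring from that of simply having a carbon group there.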